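Dropping the benzyl from the carbamate nitrogen

A few compounds are considered here, and "the series" means these few. Any claim that something is new, unique, unknown or untested is made for them only; others in the source may bear on it.

Measured compounds:
compound 1 `COC(=O)N(Cc1ccccc1F)c1c(N)nc(-c2nn(Cc3ccccc3F)c3ncccc23)nc1N`: 0.1 uM
compound 2 `COC(=O)N(Cc1cccc(F)c1)c1c(N)nc(-c2nn(Cc3ccccc3F)c3ncccc23)nc1N`: 0.2 uM
compound 3 `COC(=O)N(Cc1ccc(F)cc1)c1c(N)nc(-c2nn(Cc3ccccc3F)c3ncccc23)nc1N`: 0.7 uM

In an assay on cells for activation of Guanylate cyclase soluble subunit alpha-1 (Rattus norvegicus), read by cGMP accumulation and immunoassay, with a stated time of 10 min (on this read-out higher numbers stand for an effect only at larger amounts of compound and lower numbers for an effect already at smaller amounts), compound 3 gives the highest number of the three. The step of a 7.0-fold higher number from compound 1 to compound 3 (0.85 log units; beyond the scatter) and the step of a 3.5-fold higher number from compound 2 to compound 3 (0.54 log units; beyond the scatter) both lie beyond the scatter, while a 2.0-fold higher number from compound 1 to compound 2 (0.30 log units; within the scatter) does not. Compound 4 `COC(=O)Nc1c(N)nc(-c2nn(Cc3ccccc3F)c3ncccc23)nc1N` differs from compound 3 by hydrogen in place of 4-fluorobenzyl on an amide-type nitrogen. Among the compounds with values here, none of the measured steps removes the benzyl group; they only move its fluorine, so they bear on the new step only loosely, showing that this group's pattern shifts the number modestly. Removing it altogether is a larger change, and a further rise beyond the scatter is expected, a 2.9-fold higher number from compound 3 to compound 4 (0.46 log units; beyond the scatter). Compound 4 is therefore estimated at 2 uM, within 0.3 uM to 15 uM.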

Compound 4, minimum effective concentration: 0.3 uM
The estimate for compound 4 lay 6.7-fold (0.82 log units) above the measured number; the range from low to high includes it.
By their numbers in this assay, from the lowest: compounds 1, 2 and 4 (each within the scatter of the next, the first and the last beyond it); then compound 3.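

In this assay, the amide-type nitrogen keeps a measurable effect with only hydrogen on it, and how hydrogen compares depends on which fluorobenzyl it replaces: a 2.3-fold lower number from compound 3 to compound 4 (0.37 log units; beyond the scatter), a 1.5-fold higher number from compound 2 to compound 4 (0.18 log units; within the scatter) and a 3.0-fold higher number from compound 1 to compound 4 (0.48 log units; beyond the scatter). Thus the 4-fluorobenzyl gives a higher number than hydrogen, the 3-fluorobenzyl stays within the scatter of it, and the 2-fluorobenzyl gives a lower one. No evidence on the reason for this is available. On these data alone, what a methyl, a longer chain or an unsubstituted benzyl would give on this nitrogen remains open.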